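The compounds below may be only part of what the source reports. "The series", "measured", "known", "first", "only" and "open" are said of these compounds alone.

Measured compounds:
compound 1 `CCC(C)n1ccc2cc(/C(C)=C/C(=O)Nc3ccccc3OCCCC(=O)O)ccc21` with 67 nM
compound 2 `CCCCC(CC)n1ccc2cc(/C(C)=C/C(=O)Nc3ccccc3OCCCC(=O)O)ccc21` with 7.1 nM
compound 3 `C/C(=C\C(=O)Nc1ccccc1OCCCC(=O)O)c1ccc2c(ccn2Cc2cccc(C)c2)c1` with 250 nM

In an assay on Prostate gland for inhibition of steroid 5-alpha-reductase (Rattus norvegicus) (a lower number here means a stronger inhibitor, a higher number a weaker inhibitor), compound 1 stands second highest of the three numbers. Its nearest neighbour is compound 3, reached by a 3.7-fold higher number from compound 1 to compound 3 (0.57 log units; beyond the scatter); its furthest is compound 2, reached by a 9.4-fold lower number from compound 1 to compound 2 (0.97 log units; beyond the scatter).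

The step of interest leads from compound 1 to compound 4 `C/C(=C\C(=O)Nc1ccccc1OCCCC(=O)O)c1ccc2c(ccn2Cc2ccc(C)cc2)c1`. The change is 4-methylbenzyl in place of sec-butyl on an aromatic nitrogen.

Among the compounds with values here, two measured steps bear on it. Both exchange the group on the aromatic nitrogen for a benzyl carrying a methyl: a 3.7-fold higher number from compound 1 to compound 3 (0.57 log units; beyond the scatter) and a 35-fold higher number from compound 2 to compound 3 (1.55 log units; beyond the scatter). Both move in the same direction, towards a higher number, and both lie beyond the scatter. Nothing measured separates 3-methylbenzyl from 4-methylbenzyl, so the closest guide is compound 3. The step to compound 4 is therefore expected to be a modest rise in this assay, of about a 3.3-fold higher number from compound 1 to compound 4 (0.52 log units; beyond the scatter), with the position of the methyl on the benzyl an open question that widens the range.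

Compound 4 is thus estimated at 220 nM, expected to fall between 80 nM and 600 nM.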

Compound 4, half-maximal inhibitory concentration: 88 nM
Estimate against measurement, compound 4: 2.5-fold (0.40 log units) above, within the range that was stated.
By their numbers in this assay, from the lowest: compound 2; then compounds 1 and 4 (each within the scatter of the next); then compound 3.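

In this assay, the exchange of sec-butyl for 4-methylbenzyl on the aromatic nitrogen gives a 1.3-fold higher number from compound 1 to compound 4 (0.12 log units; within the scatter), so this position can take a group with an aromatic ring and 8 heavy atoms in place of 4 without a step beyond the scatter, something compound 3 alone had not shown. Within the data shown here, the place of the methyl on the benzyl also counts, a point the earlier compounds could not address: the step is a 2.8-fold lower number from compound 3 to compound 4 (0.45 log units; beyond the scatter), so 4-methylphenyl and 3-methylphenyl are not interchangeable on the saturated chain carbon bound to an aromatic nitrogen. The 1-ethylpentyl group of compound 2 nevertheless keeps a clear lead over this benzyl, with a 12-fold higher number from compound 2 to compound 4 (1.09 log units; beyond the scatter), and no supporting data explain any of these differences.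

The compounds shown leave open how an unsubstituted benzyl or a 4-chlorobenzyl would compare with the 4-methylbenzyl group of compound 4. They also leave open whether a longer branched chain, such as 1-propylpentyl, would go beyond the value of compound 2 at this aromatic nitrogen.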